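Two Rings Leave, One Ring Enters on the Shared Core

The source may report more compounds than this note shows. Statements on the series, on what has been measured and on what is new or still open speak of the compounds shown alone.

Measured so far:
compound 1 `O=[N+]([O-])c1ccc(S(=O)(=O)N2C[C@@H](n3cnc4c(Cl)nc(Cl)nc43)OCc3ccccc32)cc1`: 100 nM
compound 2 `O=[N+]([O-])c1ccc(S(=O)(=O)N2CC(n3cnc4c(Cl)nc(Cl)nc43)OCc3ccccc32)cc1`: 355 nM

In a functional assay on MCF7 cells (Homo sapiens) for cytotoxicity, read by sulforhodamine B assay, with a stated time of 3 days (on this read-out higher numbers stand for weaker inhibition and lower numbers for stronger inhibition), compound 1 gives 100 nM and compound 2 gives 355 nM. Going by the values given here, compound 2 therefore carries the higher of the two numbers known so far. Among the compounds with values here, the only measured step, a 3.6-fold higher number from compound 1 to compound 2 (0.55 log units; beyond the scatter), sets these two apart, and the whole of what distinguishes them is the fact that one of compounds 1 and 2 is drawn with a defined configuration and the other without, at the place where they differ: the atoms and bonds are otherwise the same.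

Compound 3 `Cc1cn(C2CN(S(=O)(=O)c3ccc([N+](=O)[O-])cc3)c3ccccc3CO2)c(=O)[nH]c1=O` is the next compound to be measured in this assay. It comes from compound 2 by a change at a different place: a group of 9 heavy atoms (5 carbon, 2 nitrogen, 2 oxygen; one six-membered aromatic ring with 2 hetero atoms) in place of a group of 11 heavy atoms (5 carbon, 4 nitrogen, 2 chlorine; one five-membered aromatic ring with 2 hetero atoms, one six-membered aromatic ring with 2 hetero atoms), on a saturated ring carbon. Within the data shown here, no measured step bears on this change; the one step in hand concerns only how a stereocentre is drawn and says nothing about exchanging the group on that saturated ring carbon. The expectation for compound 3 is therefore held loosely, as a step of a 14-fold higher number from compound 2 to compound 3 (1.15 log units; beyond the scatter), towards a higher number. Compound 3 is estimated at 5000 nM, within a range from 800 nM to 30000 nM.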

Compound 3, half-maximal inhibitory concentration: 39800 nM
Estimate against measurement, compound 3: 8.0-fold (0.90 log units) below, outside the stated range (above it).
By their numbers in this assay, from the lowest: compound 1; then compound 2; then compound 3.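

In this assay, putting the group of 9 heavy atoms in place of the group of 11 heavy atoms on the saturated ring carbon gives a 110-fold higher number from compound 2 to compound 3 (2.05 log units; beyond the scatter). Going by these compounds alone, this shows that the position next to the ring oxygen is far from indifferent to what it carries, something the earlier pair could not show, since its only step, a 3.6-fold higher number from compound 1 to compound 2 (0.55 log units; beyond the scatter), concerns how a stereocentre is drawn and leaves the group itself unchanged. Within the data shown here, nothing in the available evidence bears on why this exchange moves the number so far.

The whole group changes at once, with its five-membered aromatic ring and both chlorine atoms leaving together, so the compounds shown cannot say which of these parts accounts for the step. On these data alone, it remains open whether a smaller change, such as an amine in place of one chlorine on the group of compound 2, would keep the number close to that of compound 2, and whether a defined configuration on the saturated ring carbon would shift the number of compound 3 as it differs between compound 1 and compound 2.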